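The source may hold more compounds than are shown below. What is called first, only, known or untested is meant among the compounds shown, and "the series" means these compounds.

Measured so far in a functional assay on NCI-H460 cells (Homo sapiens) for cytotoxicity, read by sulforhodamine B assay; a higher number here means that more compound is tolerated, a lower number that less compound is tolerated:
- compound 1 `CC1=CC[C@@H]([C@@](C)(O)CCCC(C)(C)NC(=S)NN)CC1`: > 100000 nM (a limit)
- compound 2 `COc1ccc(/C=N\NC(=S)NC(C)(C)CCC[C@](C)(O)[C@@H]2CC=C(C)CC2)cc1`: > 100000 nM (a limit)

Compound 2 has no exact number in this assay. Its entry of > 100000 nM is a limit. The evidence so far comes down to the limit of > 100000 nM in this assay, at which 2 of the 2 values shown sit.

Next in the series is compound 3 `CC1=CC[C@@H]([C@@](C)(O)CCCC(C)(C)NC(=S)N/N=C\c2cccc([N+](=O)[O-])c2)CC1`, not yet measured. The change is 3-nitrophenyl in place of 4-methoxyphenyl on a carbon with a double bond to nitrogen.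

Going by the values given here, only one measured step bears on this change: a step that the two limits leave unreadable from compound 1 to compound 2. Its size cannot be read, so it gives no magnitude to carry forward. Among the compounds with values here, no measured step yet replaces one aromatic group with another, which leaves the direction of the change open. With only limits to go on, no step beyond the usual scatter is expected in this assay, although a measurable value cannot be ruled out. The expected outcome is a number no higher from compound 2 to compound 3 (the limit leaves the size open). For compound 3 the estimated value is 100000 nM, with an expected range from 30000 nM to 200000 nM.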

Compound 3, concentration lethal to 50% of the cells: > 100000 nM
Compound 3: no number, only a limit; the forecaster's own chance of this, stated with the estimate: 75%; the middle value sits exactly at the limit.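

In this assay compound 3 gives > 100000 nM, a limit and not a number. Going by these compounds alone, compound 2 also has only a limit, so no step between compound 2 and compound 3 can be read. The compounds shown leave open whether 3-nitrophenyl and 4-methoxyphenyl differ at all, and whether any member of the series reaches a measurable value in this assay.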